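Longer Side Chains on a Shared Core and Cytotoxicity

This account rests on a few compounds, and the source may have more. Where it says the series, first, only, none or still open, it means among the compounds named here.

Measured compounds:
- compound 1, `CCCCCCCCCC(=O)c1c(O)cc(C)oc1=O`: 134000 nM
- compound 2, `CCCCCCCCCCCCCC(=O)c1c(O)cc(C)oc1=O`: > 200000 nM
- compound 3, `CCCCCCCCCCc1c(O)cc(C)oc1=O`: 56000 nM

All three were tested in an ADME assay on L929 cells (Mus musculus, culture collection number NCTC 929) for cytotoxicity, read by MTT assay, with a stated time of 72 h; on this read-out higher numbers stand for weaker inhibition and lower numbers for stronger inhibition. Compound 1 gives 134000 nM in this assay. Compound 2 differs from compound 1 only by butyl in place of hydrogen on a saturated chain carbon, nine bonds along the chain from a carbonyl carbon. For compound 2 this assay reports only a limit, > 200000 nM, and not a number; (the limit of > 200000 nM in this assay, at which 1 of the 3 values shown sits). The step between them, an at least 1.4-fold higher number from compound 1 to compound 2 (0.17 log units; that floor lies within the scatter), can therefore only be given as a floor, and that floor lies within the scatter.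

Compound 3 gives 56000 nM in this assay, the lowest of the two numbers obtained; compound 1 gives a higher number, and that gap is beyond the scatter. How the core of compound 3 differs from the core of compound 1 is not broken down here.

Compound 4, `CCCCCCCCCCCCCCc1c(O)cc(C)oc1=O`, has not yet been measured. It differs from compound 3 by butyl in place of hydrogen on a saturated chain carbon, ten or more bonds along the chain from an aromatic carbon. For the measured compounds named here, this is the same kind of change as the one from compound 1 to compound 2, though the surroundings differ: there the butyl enters on a chain that runs from a carbonyl carbon, here on a chain that runs from an aromatic carbon. Compound 4 is expected to show a step of a 2.0-fold higher number from compound 3 to compound 4 (0.29 log units; within the scatter), resting on the step from compound 1 to compound 2, an at least 1.4-fold higher number from compound 1 to compound 2 (0.17 log units; that floor lies within the scatter), whose floor points towards a higher number. Compound 4 is estimated at 110000 nM, with a range from 45000 nM to 250000 nM, and a fair chance that this assay reports only a limit.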

Compound 4, half-maximal inhibitory concentration: 24100 nM
For compound 4 the middle estimate is 4.6-fold (0.66 log units) above the measured one; measured number below the stated range.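

In this assay, butyl in place of hydrogen on a saturated chain carbon, ten or more bonds along the chain from an aromatic carbon, gives a 2.3-fold lower number from compound 3 to compound 4 (0.37 log units; beyond the scatter), so here the longer chain goes with stronger inhibition of the cells. The same change does not carry over from one core to the other as a fixed shift, and the two steps do not agree: the same change on two cores in this assay, an at least 1.4-fold higher number (0.17 log units; that floor lies within the scatter) from compound 1 to compound 2 and a 2.3-fold lower number (0.37 log units; beyond the scatter) from compound 3 to compound 4, at least 3.4-fold (0.54 log units) apart, beyond the scatter of two such steps Compound 2 is reported only as a limit, so the full size of the earlier step stays unknown, the gap between the two steps is only a lower bound, and nothing here explains why the cores part ways: the limit of > 200000 nM in this assay, at which 1 of the 4 values shown sits.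

The compounds shown leave open how the number moves at chain lengths between and beyond these, so one pair of steps on each core gives no general rule for chain length, and a longer chain on either core could follow either trend. They also leave open whether a chain ending in an amine or a carboxylic acid would behave like these plain carbon chains on either core.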